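The source may report more compounds than this note shows. Statements on the series, on what has been measured and on what is new or still open speak of the compounds shown alone.

In an ADME assay on MT4 cells (Homo sapiens) for cytotoxicity, read by MTT assay (a higher number here means that more compound is tolerated, a lower number that less compound is tolerated), compound 2 (`CCCC1C(=O)N(O)C(=O)c2ccccc21`) gives 25400 nM as the middle of three numbers, with compound 1 (`Cc1ccc(CC2C(=O)N(O)C(=O)c3ccccc32)cc1`) at 5500 nM on the low side and compound 3 (`CC(C)C1C(=O)N(O)C(=O)c2ccccc21`) at 123000 nM on the high side. Compound 4 (`O=C1c2ccccc2C(CCCc2ccccc2)C(=O)N1O`) differs from compound 2 by phenyl in place of hydrogen on a saturated chain carbon, three bonds along the chain from a saturated ring carbon. The nearest measured change is a 4.6-fold higher number from compound 1 to compound 2 (0.66 log units; beyond the scatter) as 4-methylphenyl gives way to ethyl, so adding a phenyl ring points to a lower number, by a similar step beyond the scatter. The other change, a 4.8-fold higher number from compound 2 to compound 3 (0.69 log units; beyond the scatter) for isopropyl in place of propyl, adds no ring and bears less. The estimated step is a 3.6-fold lower number from compound 2 to compound 4 (0.56 log units; beyond the scatter) in that direction. Compound 4 is expected at 7000 nM, taking 2500 nM to 20000 nM as its range.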

Compound 4, half-maximal cytotoxic concentration: 5200 nM
Estimate against measurement, compound 4: 1.3-fold (0.13 log units) above, and the stated range covers the measured number.
By their numbers in this assay, from the lowest: compounds 4 and 1 (each within the scatter of the next); then compound 2; then compound 3.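

In this assay adding phenyl to the end of the propyl chain, on the saturated chain carbon three bonds along from the saturated ring carbon, gives a 4.9-fold lower number from compound 2 to compound 4 (0.69 log units; beyond the scatter) and so a clear drop in the concentration tolerated. Within the data shown here, earlier, the one step involving a ring swapped 4-methylphenyl for ethyl, whereas here the ring is the only change on an otherwise unchanged chain. The evidence at hand gives no reason for this drop.

As far as these compounds go, whether an amine or a carboxylic acid in place of phenyl would also lower the number remains open. So does whether a longer chain without any ring would do so.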